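The compounds below may be only part of what the source reports. "The series", "measured", "known", "first", "only" and "open" are said of these compounds alone.

Compound 3 `Fc1cccc(-c2nc(Nc3ccc(Br)cc3)c3cc(F)ccc3n2)c1` is known in a functional assay on MDA-MB-231 cells (Homo sapiens) for cytotoxicity, read by MTT assay, with a stated time of 48 h (a higher number here means a weaker inhibitor, a lower number a stronger inhibitor), only by a limit, > 50000 nM, not by a number. Compound 2 `Fc1cccc(-c2nc(Nc3ccc(Cl)cc3)c3cc(F)ccc3n2)c1` likewise returns only a limit, > 50000 nM. Going by the values given here, the one numerical value comes from compound 1 `COc1ccc(Nc2nc(-c3cccc(F)c3)nc3ccc(F)cc23)cc1`, which in this assay gives 47300 nM. The move an at least 1.0-fold higher number from compound 1 to compound 2 (0.02 log units; that floor lies within the scatter) and the move an at least 1.0-fold higher number from compound 1 to compound 3 (0.02 log units; that floor lies within the scatter) are each a floor rather than a step, and the pair of limits leaves a step that the two limits leave unreadable from compound 2 to compound 3 unreadable; two of the three compounds sit on (the limit of > 50000 nM in this assay, at which 2 of the 3 values shown sit).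

Compound 4 `Fc1cccc(-c2nc(Nc3ccccc3Br)c3cc(F)ccc3n2)c1` differs from compound 3 in one place: 2-bromophenyl in place of 4-bromophenyl on a nitrogen on an aromatic ring. Among the compounds with values here, none of the measured steps moves a substituent to another position of that ring; they all exchange groups at the same place, and two of them end at a limit. Within the data shown here, there is therefore no measured step on which a direction could rest, and no step beyond the scatter is expected, so compound 4 is estimated to sit near the limit itself, at 50000 nM within 15000 nM to 150000 nM, which means an expected step of a number no higher from compound 3 to compound 4 (the limit leaves the size open).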

Compound 4, half-maximal inhibitory concentration: > 50000 nM
Compound 4 ended at the assay's limit; the forecaster's own chance of this, stated with the estimate: 60%; the middle value lies on the limit itself.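

In this assay compound 4 gives > 50000 nM, which is a limit of the assay and not a number. Going by these compounds alone, the steps to compound 4 from compound 2 and compound 3 cannot be read, and the one readable step, an at least 1.0-fold higher number from compound 1 to compound 4 (0.02 log units; that floor lies within the scatter), is only a floor. What is new is that a change of place on the ring, and not only an exchange of groups, also ends at the limit, so neither the 2-bromophenyl nor the 4-bromophenyl group gives a readable number here: the limit of > 50000 nM in this assay, at which 3 of the 4 values shown sit.

Going by these compounds, how far compound 3 and compound 4 lie past the limit stays open, and so does whether they differ at all. Also open, on these data alone, is whether an amine or a carboxylic acid on the phenyl ring, in place of the bromine, would bring a compound back to a readable number.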